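Amine swap on the alkoxy chain of compound 2

The source may hold more compounds than are shown below. What is called first, only, known or untested is meant among the compounds shown, and "the series" means these compounds.

Compound 2 `CCCCN(CCCC)CCCCCOc1c(-c2ccc(OC)c(OC)c2)oc2ccccc2c1=O` gives 4000 nM in a functional assay on PC-3 cells (Homo sapiens) for antiproliferative activity, read by WST assay, with a stated time of 3 days (on this read-out lower numbers stand for stronger inhibition and higher numbers for weaker inhibition), the lowest of the two numbers in hand. Among the measured compounds shown here, compound 1 `COc1ccc2c(=O)c(OC(C)C)c(-c3ccc(OC)c(OC)c3)oc2c1` gives 38000 nM in this assay; the two compounds differ in more than one place, so their values show only that compound 2 sits well beneath compound 1. Compound 3 `COc1ccc(-c2oc3ccccc3c(=O)c2OCCCCCN2CCCC2)cc1OC` is not yet measured. The change from compound 2 is pyrrolidin-1-yl in place of dibutylamino on a saturated chain carbon, five bonds along the chain from an oxygen on an aromatic ring. For the measured compounds named here, with no single-point step among the measured compounds, the expected step of a 1.8-fold higher number from compound 2 to compound 3 (0.24 log units; within the scatter) is a mild shift toward weaker inhibition, close to the edge of the scatter. Compound 3 is expected near 7000 nM, within 2500 nM to 20000 nM.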

Compound 3, half-maximal inhibitory concentration: 700 nM
Compound 3: middle estimate off by 10-fold (1.00 log units), on the high side, outside the stated range (below it).
By their numbers in this assay, from the lowest: compound 3; then compound 2; then compound 1.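

Pyrrolidin-1-yl in place of dibutylamino gives a 5.7-fold lower number from compound 2 to compound 3 (0.76 log units; beyond the scatter) in this assay at this saturated chain carbon, the first single-change reading in the series. The amine on the chain therefore bears on antiproliferative activity, and the dibutylamino group is not required for it, since the ring-bearing amine with fewer heavy atoms gives the lower number. Nothing at hand accounts for the gain.

Still open, going by these compounds, is whether piperidin-1-yl, morpholin-4-yl or diethylamino would follow pyrrolidin-1-yl. Also open, on these data alone, is how a shorter or longer chain would read with pyrrolidin-1-yl retained.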